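The compounds below may be only part of what the source reports. "The series", "measured", "known", "first", "only" and "open" are said of these compounds alone.

For the measured compounds named here, in a functional assay on A549 cells (Homo sapiens) for antiproliferative activity, read by MTT assay, with a stated time of 72 h (on this read-out higher numbers stand for weaker inhibition and lower numbers for stronger inhibition), compound 1 `COc1cc(-n2cnc3ccc(-c4ccc([N+](=O)[O-])cc4)cc32)cc(OC)c1OC` gives 8940 nM, the highest of the two numbers measured so far. Going by the values given here, compound 2 `COc1cccc(-c2ccc3ncn(-c4cc(OC)c(OC)c(OC)c4)c3c2)c1` gives 3180 nM, and the one measured step is a 2.8-fold lower number from compound 1 to compound 2 (0.45 log units; beyond the scatter). Compound 3 `COc1cc(-n2cnc3ccc(-c4ccc(O)cc4)cc32)cc(OC)c1OC` has not yet been measured; it differs from compound 1 by hydroxy in place of nitro on an aromatic carbon. Among the compounds with values here, only the step from compound 1 to compound 2 bears on this, and it brings in a different group, so it is weak guidance. The step is expected to be a 1.8-fold lower number from compound 1 to compound 3 (0.25 log units; within the scatter), modest or perhaps within the scatter. Compound 3 is therefore expected to give 5000 nM, in the range 2000 nM to 12000 nM.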

Compound 3, half-maximal inhibitory concentration: 5090 nM
The estimate for compound 3 lay 1.0-fold (0.01 log units) below the measured number; the measured number falls inside the stated range.
By their numbers in this assay, from the lowest: compounds 2, 3 and 1 (each within the scatter of the next, the first and the last beyond it).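

Hydroxy in place of nitro on this aromatic carbon gives a 1.8-fold lower number from compound 1 to compound 3 (0.24 log units; within the scatter) in this assay, so these two groups cannot be told apart on this read-out. Compound 3 also stays within the scatter of compound 2, with a 1.6-fold higher number from compound 2 to compound 3 (0.20 log units; within the scatter) for 4-hydroxyphenyl in place of 3-methoxyphenyl. Only compound 1 and compound 2 therefore remain separated beyond the scatter.

From the compounds shown here alone, whether an amine or a carboxylic acid at this position would give a clearly different number remains open. No measurement available here accounts for these numbers.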